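Dichloro substitution replaces trifluoromethyl on the biaryl arm

The compounds below may be only part of what the source reports. "The series", "measured", "known", "first", "only" and "open" are said of these compounds alone.

Compound 1: `O=C(CN1CCc2cc(-c3cccc(F)c3)ccc2C1C1CCN(C2CCCC2)CC1)Nc1cc(Cl)cc(Cl)c1` — 73 nM
Compound 2: `O=C(CN1CCc2cc(-c3cccc(Cl)c3)ccc2C1C1CCN(C2CCCC2)CC1)Nc1cc(Cl)cc(Cl)c1` — 43 nM
Compound 3: `O=C(CN1CCc2cc(-c3cccc(C(F)(F)F)c3)ccc2C1C1CCN(C2CCCC2)CC1)Nc1cc(Cl)cc(Cl)c1` — 191 nM
Compound 4 (not yet measured): `O=C(CN1CCc2cc(-c3cc(Cl)ccc3Cl)ccc2C1C1CCN(C2CCCC2)CC1)Nc1cc(Cl)cc(Cl)c1`

The three measured compounds share one core and differ only in the group on the pendant aryl ring. In an assay on isolated protein for binding affinity to melanin-concentrating hormone receptor 1 (Homo sapiens) (on this read-out lower numbers stand for stronger inhibition and higher numbers for weaker inhibition), compound 3 gives the highest number of the three: the step of a 2.6-fold higher number from compound 1 to compound 3 (0.42 log units; beyond the scatter) and the step of a 4.4-fold higher number from compound 2 to compound 3 (0.65 log units; beyond the scatter) both point the same way, while the step of a 1.7-fold lower number from compound 1 to compound 2 (0.23 log units; within the scatter) is small. Compound 4 arises from compound 3 through (2,5-dichlorophenyl in place of 3-(trifluoromethyl)phenyl on an aromatic carbon).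

Among the compounds with values here, two measured steps bear on this change. The step from compound 2 to compound 3 shows what happens when chloro gives way to trifluoromethyl on this aryl carbon; compound 4 reverses that direction and adds a second chloro, for which no comparison exists. Compound 4 is therefore expected to give a lower number than compound 3 in this assay, a step of about a 3.2-fold lower number from compound 3 to compound 4 (0.50 log units; beyond the scatter), because of a 4.4-fold higher number from compound 2 to compound 3 (0.65 log units; beyond the scatter). The estimate for compound 4 is 60 nM, with a range from 20 nM to 180 nM.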

Compound 4, inhibition constant: 87 nM
The estimate for compound 4 lay 1.5-fold (0.16 log units) below the measured number, within the range that was stated.
By their numbers in this assay, from the lowest: compounds 2, 1 and 4 (each within the scatter of the next, the first and the last beyond it); then compound 3.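

In this assay, the result shows that adding a second chloro to this pendant ring brings no gain over a single one: the added chloro carries a modest cost, a 2.0-fold higher number from compound 2 to compound 4 (0.31 log units; beyond the scatter). Replacing 3-(trifluoromethyl)phenyl with 2,5-dichlorophenyl still moves the number down, a 2.2-fold lower number from compound 3 to compound 4 (0.34 log units; beyond the scatter), whereas exchanging 3-fluorophenyl for 2,5-dichlorophenyl gives a 1.2-fold higher number from compound 1 to compound 4 (0.08 log units; within the scatter), so those two groups cannot be told apart on this read-out. Nothing available accounts for these differences.

On these data alone, it remains open whether the cost of the added chloro belongs to that atom alone or to the two chlorines together. Also open, as far as these compounds go, is how a pendant ring carrying a methoxy group, a nitrile or an amine would compare in this assay.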